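Notes on carbamate and carbonate analogues of the shared core

A few compounds are considered here, and "the series" means these few. Any claim that something is new, unique, unknown or untested is made for them only; others in the source may bear on it.

Compound 1 `CCNC(=O)OC[C@H]1O[C@@H](n2cnc3c(N)ncnc32)[C@H](O)[C@@H]1O` carries an ethylcarbamoyl group on the shared core. In an assay on COS-7 cells for inhibition of sodium/nucleoside cotransporter 2 (Homo sapiens), read by scintillation counting, in the presence of a further agent that is not named here (a higher number here means a weaker inhibitor, a lower number a stronger inhibitor), compound 1 gives > 100000 nM, which is a limit of the assay and not a number. Two analogues of the same core carry instead a substituent on a saturated chain carbon bound to a nitrogen on an aromatic ring: compound 2 `Nc1ncnc2c1nc(NCc1ccccc1Cl)n2[C@@H]1O[C@H](CO)[C@@H](O)[C@H]1O` gives 5700 nM in this assay, and compound 3 `Nc1ncnc2c1nc(NCc1ccc3ccccc3c1)n2[C@@H]1O[C@H](CO)[C@@H](O)[C@H]1O` gives 5300 nM. Among the measured compounds shown here, the single measured step, a 1.1-fold lower number from compound 2 to compound 3 (0.03 log units; within the scatter), concerns the aryl group on that chain and says nothing about the carbonyl end of compound 1. Compound 1 thus stands at the limit, (the limit of > 100000 nM in this assay, at which 1 of the 3 values shown sits), apart from the two numbered values.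

Compound 4 `CCCCCOC(=O)OC[C@H]1O[C@@H](n2cnc3c(N)ncnc32)[C@H](O)[C@@H]1O` is the next target: pentyloxy in place of ethylamino on a carbonyl carbon. For the measured compounds named here, no measured step touches this carbonyl carbon, so no size can be read across from compounds 2 and 3; the only guide is that compound 1 sits at the limit. In this assay compound 4 is therefore expected to remain near that limit, with a step that the limit leaves unreadable from compound 1 to compound 4 expected to lie within the scatter. The estimate for compound 4 is 150000 nM, with a range from 40000 nM to 600000 nM.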

Compound 4, half-maximal inhibitory concentration: > 100000 nM
Compound 4: no number, only a limit; the forecaster's own chance of this, stated with the estimate: 80%; the middle value is on the limit's open side.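

In this assay compound 4 gives > 100000 nM, a limit of the assay and not a number. Compound 1 also stands at a limit, so no step between compound 1 and compound 4 can be read: the limit of > 100000 nM in this assay, at which 2 of the 4 values shown sit.

The compounds shown leave open how pentyloxy and ethylamino on a carbonyl carbon compare in this assay.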